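Sulfonamide side chains on a shared kinase-inhibitor core

A few compounds are considered here, and "the series" means these few. Any claim that something is new, unique, unknown or untested is made for them only; others in the source may bear on it.

Compound 1 `O=S(=O)(NCCN1CCCCC1)c1ccc(-c2ccnc3[nH]ccc23)cc1` carries a sulfonamide whose nitrogen bears a 2-(piperidin-1-yl)ethyl chain. In an assay on isolated protein for inhibition of serine/threonine-protein kinase Nek1 (Homo sapiens), read by TR-FRET, with a stated time of 30 min (a higher number here means a weaker inhibitor, a lower number a stronger inhibitor), compound 1 gives 6600 nM, the highest of the two numbers recorded here. Compound 2 `COCCNS(=O)(=O)c1ccc(-c2ccnc3[nH]ccc23)cc1` replaces the piperidine with a methoxy group; its result in this assay is only a limit, > 30000 nM, meaning the assay could not place a number on it (the limit of > 30000 nM in this assay, at which 1 of the 3 values shown sits). Compound 3 `CN(CCO)S(=O)(=O)c1ccc(-c2ccnc3[nH]ccc23)cc1` carries a (2-hydroxyethyl)(methyl)amino group on the sulfonyl sulfur and gives 2700 nM in this assay.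

Compound 4 `CC(C)(O)CNS(=O)(=O)c1ccc(-c2ccnc3[nH]ccc23)cc1` differs from compound 1 in one place: 1-hydroxy-1-methylethyl in place of (piperidin-1-yl)methyl on a saturated chain carbon bound to a sulfonamide nitrogen. Among the measured compounds shown here, two measured steps bear on this. Removing the basic ring in favour of an ether gave an at least 4.5-fold higher number from compound 1 to compound 2 (0.65 log units; beyond the scatter), while exchanging it for a hydroxyl-bearing chain gave a 2.4-fold lower number from compound 1 to compound 3 (0.39 log units; beyond the scatter); between those two compounds the change was an at least 11-fold lower number from compound 2 to compound 3 (1.04 log units; beyond the scatter). Compound 4 keeps the hydroxyl found in compound 3 but also the sulfonamide hydrogen found in compound 2, so the two precedents pull in opposite directions. The expected step is therefore a 1.1-fold lower number from compound 1 to compound 4 (0.04 log units; within the scatter), no larger than the scatter. Compound 4 is estimated at 6000 nM, within a range of 2000 nM to 25000 nM.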

Compound 4, half-maximal inhibitory concentration: 5800 nM
Beside the measured number, compound 4's estimate is 1.0-fold (0.01 log units) above it, and the stated range covers the measured number.
By their numbers in this assay, from the lowest: compound 3; then compounds 4 and 1 (each within the scatter of the next). At a limit, above all of these: compound 2.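

In this assay, the piperidine ring on this chain is not needed to keep the number where it was: 1-hydroxy-1-methylethyl in place of (piperidin-1-yl)methyl, on a saturated chain carbon bound to a sulfonamide nitrogen, gives a 1.1-fold lower number from compound 1 to compound 4 (0.06 log units; within the scatter), even though the entering group has no ring and fewer heavy atoms. Against methoxymethyl at the same place, the same group gives an at least 5.1-fold lower number from compound 2 to compound 4 (0.71 log units; beyond the scatter), a step whose starting point is only a limit of the assay: the limit of > 30000 nM in this assay, at which 1 of the 4 values shown sits A hydroxyl-bearing chain therefore gives a measurable number with the sulfonamide hydrogen kept, so the methyl on the sulfonamide nitrogen of compound 3 is not required for one, although compound 3 still holds the lower number, with a 2.1-fold higher number from compound 3 to compound 4 (0.33 log units; beyond the scatter).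

On these data alone, it remains open whether the hydroxyl or the methyl branching of the 1-hydroxy-1-methylethyl group carries the step from methoxymethyl, and whether the methyl on the sulfonamide nitrogen accounts for the lower number of compound 3. The compounds shown also leave open how a primary amine, a carboxylic acid or a longer chain ending in a hydroxyl would behave at this place.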